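This account rests on a few compounds, and the source may have more. Where it says the series, first, only, none or still open, it means among the compounds named here.

Measured compounds:
compound 1 `Nc1scc(CN2CCN(c3ccc(F)cc3Cl)CC2)c1C(=O)c1ccc(Cl)cc1`: 0%
compound 2 `COc1ccc(N2CCN(Cc3csc(N)c3C(=O)c3ccc(Cl)cc3)CC2)cc1`: 0%
compound 3 `Nc1scc(CN2CCN(c3c(F)cc(F)cc3F)CC2)c1C(=O)c1ccc(Cl)cc1`: 0%

All three share one core and differ only in the aryl group carried on the amine nitrogen in the piperazine-type ring. In an assay on CHO cells for displacement of a labelled ligand from adenosine receptor A1 (Homo sapiens), read by scintillation counting, with a stated time of 120 min, tested at 10 uM (on this read-out lower numbers stand for less inhibition and higher numbers for more inhibition at the one concentration tested (going by the name of the read-out)), compound 1 stands level with compound 2 and compound 3; none of the three shows any inhibition at the digits read. The steps among them bear this out: no change at the digits printed from compound 1 to compound 2 (within the scatter), no change at the digits printed from compound 1 to compound 3 (within the scatter) and no change at the digits printed from compound 2 to compound 3 (within the scatter). Three different aryl groups at this one place, with methoxy, with a single chlorine and fluorine, or with three fluorines, leave the read-out flat.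

Compound 4 `Nc1scc(CN2CCN(c3ccc(F)c(Cl)c3)CC2)c1C(=O)c1ccc(Cl)cc1` is the next member of the same set. Its difference from compound 1 is 3-chloro-4-fluorophenyl in place of 2-chloro-4-fluorophenyl on an amine nitrogen in a ring. Since every change so far at this same place, from compound 1 to compound 2, from compound 1 to compound 3 and from compound 2 to compound 3, was without effect, the step of no change at the digits printed from compound 1 to compound 4 (within the scatter) is expected to be none beyond the scatter. Compound 4 is therefore estimated at 0%, within -5% to 10%.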

Compound 4, a percentage reported as inhibition, at one concentration (the size of the read-out at that concentration, not a potency): 0%
The estimate for compound 4 equals the measured number at the digits printed, and the stated range covers the measured number.
By their numbers in this assay, from the lowest: compounds 1, 2, 3 and 4 (each within the scatter of the next).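

The change tested here is new in kind: 3-chloro-4-fluorophenyl holds the same atoms as 2-chloro-4-fluorophenyl, joined differently, and in this assay this gives no change at the digits printed from compound 1 to compound 4 (within the scatter). The comparisons with the other two aryl groups read the same, with no change at the digits printed from compound 3 to compound 4 (within the scatter) and no change at the digits printed from compound 2 to compound 4 (within the scatter), so moving the chlorine on the aryl group on this amine nitrogen adds no separation among the four compounds. No measured evidence is available that bears on this flat result.

With all four compounds showing no inhibition in this assay, the series gives no starting point for ranking aryl groups at this place. Still open, going by these compounds, is whether an aryl group carrying a carboxylic acid or an amine, or a longer chain on this nitrogen, would give any inhibition.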